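The source may report more compounds than this note shows. Statements on the series, on what has been measured and on what is new or still open speak of the compounds shown alone.

Measured so far in an ADME assay on BHK-21 cells (Mesocricetus auratus) for cytotoxicity, read by MTT assay, with a stated time of 96 h; on this read-out lower numbers stand for higher toxicity in this test and higher numbers for lower toxicity in this test:
- Compound 1 `Fc1ccc(F)c(/N=N/Nc2ccccc2)c1` gives > 100000 nM (a limit of the assay, not a number)
- Compound 2 `CN(C)CCCN(/N=N/c1cc(F)ccc1F)c1ccccc1` gives 25000 nM (the only true number so far)

With one result a limit, compound 2 has no measured number to be ranked against. Compound 3 `CN(C)CCCN(/N=N/c1cc(F)ccc1F)c1cccc(C(F)(F)F)c1` is compound 2 with a single change, trifluoromethyl in place of hydrogen on an aromatic carbon, meta to a large group (trifluoromethyl in place of hydrogen on an aromatic carbon). Among the measured compounds shown here, only one measured step exists to guide an expectation. It is an at least 4.0-fold lower number from compound 1 to compound 2 (0.60 log units; beyond the scatter), and it put a 3-(dimethylamino)propyl group in place of hydrogen on a nitrogen. That is a different group in a different place, so it offers only a weak hint, but its direction is downward. A small move to a lower number is expected for compound 3, and it may well stay within the usual scatter. The estimate amounts to a 1.7-fold lower number from compound 2 to compound 3 (0.22 log units; within the scatter) as the expected step. Compound 3 is estimated at 15000 nM, with 5000 nM to 50000 nM as the expected range.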

Compound 3, half-maximal cytotoxic concentration: 54000 nM
The estimate for compound 3 lay 3.6-fold (0.56 log units) below the measured number; the measured number lies above the stated range.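

In this assay, placing trifluoromethyl on an aromatic carbon of the six-membered aromatic ring gives a 2.2-fold higher number from compound 2 to compound 3 (0.33 log units; beyond the scatter), so at this place the added group goes with lower toxicity in this test, by a modest step. Among the compounds shown here, the only earlier step, an at least 4.0-fold lower number from compound 1 to compound 2 (0.60 log units; beyond the scatter), ran the other way, with a different group at a different place, so the number can move in either direction depending on the change made. This new step also has true numbers at both ends, whereas the earlier one starts from a limit, and the top of the measurable range does not cut it off because only compound 1 sits there: the limit of > 100000 nM in this assay, at which 1 of the 3 values shown sits.

With a single pair, the compounds shown leave open whether this rise belongs to trifluoromethyl itself or would also follow a chlorine atom, a methoxy group or a nitrile at the same place. They also leave open whether the same rise would appear with a longer chain in place of the 3-(dimethylamino)propyl group, or with trifluoromethyl on another carbon of that ring.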